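The source may hold more compounds than are shown below. What is called first, only, known or untested is meant among the compounds shown, and "the series" means these compounds.

Working notes on the series. Compound 1 `CC(C)(C)c1ccc(C(=O)N2CCC3(CC2)C(=O)N(CC(=O)N2CCC(CCO)CC2)CN3c2ccccc2)cc1` is measured in an assay on HEK293 cells for displacement of a labelled ligand from NPC1-like intracellular cholesterol transporter 1 (Homo sapiens) (a lower number here means a stronger inhibitor, a higher number a weaker inhibitor), at 2600 nM. Compound 2 `CC(C)(C)OC(=O)NCNC(=O)CN1CN(c2ccccc2)C2(CCN(C(=O)c3ccc(C4CCCCC4)cc3)CC2)C1=O` gives 1700 nM in this assay; the two numbers lie within the usual scatter of each other, so neither compound separates from the other. Compound 3 `CCOC(=O)C1CCN(C(=O)CN2CN(c3ccccc3)C3(CCN(C(=O)c4ccc(C(C)(C)C)cc4)CC3)C2=O)CC1` is not yet measured. Against compound 1 the change is ethoxycarbonyl in place of 2-hydroxyethyl on a saturated ring carbon. For the measured compounds named here, no measured pair in the set shows this change, so the step of a 1.2-fold lower number from compound 1 to compound 3 (0.07 log units; within the scatter) is expected to stay small, with no clear direction beyond the scatter. Compound 3 is expected near 2200 nM, range 800 nM to 6000 nM.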

Compound 3, half-maximal inhibitory concentration: 3100 nM
Beside the measured number, compound 3's estimate is 1.4-fold (0.15 log units) below it, and the stated range covers the measured number.
By their numbers in this assay, from the lowest: compounds 2, 1 and 3 (each within the scatter of the next).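

On the saturated ring carbon three ring bonds from the ring nitrogen, ethoxycarbonyl in place of 2-hydroxyethyl gives a 1.2-fold higher number from compound 1 to compound 3 (0.08 log units; within the scatter) in this assay, so this exchange does not separate the two compounds. Ethoxycarbonyl carries no hydrogen-bond donor, unlike 2-hydroxyethyl, yet the two numbers remain within the scatter of each other. No supporting measurement bears on this result.

Going by these compounds, whether a carboxylic acid, a primary amine or a longer alkyl chain on this ring carbon would move the number beyond the scatter remains open.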